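Working notes: the step from compound 3 to compound 4

A few compounds are considered here, and "the series" means these few. Any claim that something is new, unique, unknown or untested is made for them only; others in the source may bear on it.

Measured in a functional assay on KMS-11 cells (Homo sapiens) for antiproliferative activity, read by CellTiter-Glo, with a stated time of 72 h; on this read-out lower numbers stand for stronger inhibition and higher numbers for weaker inhibition:
compound 1 `COc1ccc(C(=O)N(Cc2ccncc2)Cc2cccc(OCCc3ccc(C)cc3)c2)cc1` gives 9100 nM
compound 2 `COc1ccc(C(=O)N(Cc2ccncc2)Cc2cccc(OCCc3ccccc3)c2)cc1` gives 16900 nM
compound 3 `COc1ccc(C(=O)N(Cc2ccncc2)Cc2cccc(OCCc3ccc(Br)cc3)c2)cc1` gives 8400 nM

Compound 3 cannot be separated from the other two, with a 1.1-fold lower number from compound 1 to compound 3 (0.03 log units; within the scatter) and a 2.0-fold lower number from compound 2 to compound 3 (0.30 log units; within the scatter). Compound 4 `COc1ccc(C(=O)N(Cc2ccncc2)Cc2cccc(OCc3ccc([N+](=O)[O-])cc3)c2)cc1` is still unmeasured. The change is 4-nitrophenyl in place of 4-bromobenzyl on a saturated chain carbon bound to an oxygen on an aromatic ring. The nearest evidence is the ring substituent swaps, with a 1.9-fold higher number from compound 1 to compound 2 (0.27 log units; within the scatter) as the remaining step, and all stay within the scatter. For the measured compounds named here, no measured step covers 2-(4-bromophenyl)ethoxy going to (4-nitrobenzyl)oxy, so the range stays wide. No shift beyond the scatter is expected in this assay, and the expected step is a 1.2-fold higher number from compound 3 to compound 4 (0.08 log units; within the scatter). The estimate for compound 4 is 10000 nM, with an expected range of 3500 nM to 30000 nM.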

Compound 4, half-maximal inhibitory concentration: 15400 nM
The estimate for compound 4 lay 1.5-fold (0.19 log units) below the measured number, and the stated range covers the measured number.
By their numbers in this assay, from the lowest: compounds 3, 1, 4 and 2 (each within the scatter of the next).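

The replacement of 2-(4-bromophenyl)ethoxy by (4-nitrobenzyl)oxy changes the chain and its ring substituent together, yet in this assay the result stays within the scatter (a 1.8-fold higher number from compound 3 to compound 4 (0.26 log units; within the scatter)). The same holds against the other two compounds (a 1.1-fold lower number from compound 2 to compound 4 (0.04 log units; within the scatter); a 1.7-fold higher number from compound 1 to compound 4 (0.23 log units; within the scatter)), so this position has not yet given a separable difference. No further evidence bears on this result.

The separate contributions of the chain and the nitro group remain unresolved. Also open, going by these compounds, is whether an amine, a carboxylic acid or a longer chain in this place would move the number beyond the scatter.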